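The source may report more compounds than this note shows. Statements on the series, on what has been measured and on what is new or still open speak of the compounds shown alone.

Working notes on the series. In a functional assay on SMMC-7721 cells (Homo sapiens) for cytotoxicity, read by MTT assay, with a stated time of 72 h (on this read-out higher numbers stand for weaker inhibition and lower numbers for stronger inhibition), compound 3 `CCCCCOCNc1n[n+]([O-])c2ccccc2[n+]1[O-]` gives 3050 nM, the second highest of the three numbers: compound 2 `[O-][n+]1nc(NCOC2CCCCC2)[n+]([O-])c2ccccc21` gives 4170 nM, and compound 1 `COc1ccc2c(c1)[n+]([O-])nc(NCOC(C)c1ccccc1)[n+]2[O-]` gives 740 nM. For the measured compounds named here, the one measured step, a 1.4-fold lower number from compound 2 to compound 3 (0.14 log units; within the scatter), shows that exchanging the group on the oxygen changed nothing beyond the scatter. Compound 4 `[O-][n+]1nc(NCOCc2ccc(Cl)cc2)[n+]([O-])c2ccccc21` differs from compound 3 by 4-chlorophenyl in place of butyl on a saturated chain carbon bound to an oxygen on a saturated carbon. Going by the values given here, compound 1 carries an aromatic ring in the same region and gives the lowest number, but it also differs in its core, so no step to it is available. Among the compounds with values here, on the single bearing step the change in this assay is expected to be small; compound 4 is estimated at 1800 nM (range 700 nM to 4500 nM), a step of a 1.7-fold lower number from compound 3 to compound 4 (0.23 log units; within the scatter).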

Compound 4, half-maximal inhibitory concentration: 810 nM
Estimate against measurement, compound 4: 2.2-fold (0.35 log units) above; the measured number falls inside the stated range.
By their numbers in this assay, from the lowest: compounds 1 and 4 (each within the scatter of the next); then compounds 3 and 2 (each within the scatter of the next).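

In this assay, for the compounds shown here, the change to 4-chlorophenyl in place of butyl gives a 3.8-fold lower number from compound 3 to compound 4 (0.58 log units; beyond the scatter) and so yields the first step beyond the scatter. The earlier exchange on the oxygen, a 1.4-fold lower number from compound 2 to compound 3 (0.14 log units; within the scatter), showed no such response, whereas this position on a saturated chain carbon bound to an oxygen on a saturated carbon does respond to the group it carries. No evidence at hand bears on the reason for this step.

On these data alone, whether the aromatic ring or its chlorine carries the step remains open. A 4-fluorophenyl group or an amine in the same place would help separate the two.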